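This account rests on a few compounds, and the source may have more. Where it says the series, first, only, none or still open, it means among the compounds named here.

Measured so far:
Compound 1 `CC(=O)OC[C@H]1O[C@@H](n2cc(CN3C(=O)/C(=C/C=C/c4ccccc4)c4ccccc43)nn2)[C@H](OC(C)=O)[C@@H](OC(C)=O)[C@@H]1OC(C)=O` — 12300 nM
Compound 2 `CC(=O)OC[C@H]1O[C@@H](n2cc(CN3C(=O)/C(=C/c4ccco4)c4ccccc43)nn2)[C@H](OC(C)=O)[C@@H](OC(C)=O)[C@@H]1OC(C)=O` — 31800 nM

In an ADME assay on NIH3T3 cells (Homo sapiens) for cytotoxicity, read by sulforhodamine B assay, with a stated time of 48 h (a lower number here means a stronger inhibitor, a higher number a weaker inhibitor), compound 1 gives 12300 nM and compound 2 gives 31800 nM. Compound 2 therefore stands with the higher of the two numbers, and the gap to compound 1 is beyond the scatter: a 2.6-fold higher number from compound 1 to compound 2 (0.41 log units; beyond the scatter). Both share the same core, and the only difference between them sits on a double-bonded chain carbon bound to a double-bonded ring carbon.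

Compound 3 `CCC/C=C1/C(=O)N(Cc2cn([C@@H]3O[C@H](COC(C)=O)[C@@H](OC(C)=O)[C@H](OC(C)=O)[C@H]3OC(C)=O)nn2)c2ccccc21` keeps that core and differs from compound 2 in one place: propyl in place of furan-2-yl on a double-bonded chain carbon bound to a double-bonded ring carbon. Among the measured compounds shown here, only one measured step bears on this change, the one from compound 1 to compound 2, in which an aromatic group of three fewer ring atoms replaced a larger one at the same place and gave a modestly higher number. The move to propyl removes the ring altogether, so a further rise in this assay of similar or modest size is expected, though a step within the scatter cannot be ruled out. Compound 3 is therefore estimated at 45000 nM in this assay, in the range 18000 nM to 110000 nM, corresponding to an expected step of a 1.4-fold higher number from compound 2 to compound 3 (0.15 log units; within the scatter).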

Compound 3, half-maximal inhibitory concentration: > 100000 nM
Compound 3 ended at the assay's limit; the forecaster's own chance of this, stated with the estimate: 20%; middle value at least 2.2-fold (0.34 log units) from the limit.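

In this assay, compound 3 ends at a limit of the assay and not at a number: the limit of > 100000 nM in this assay, at which 1 of the 3 values shown sits.

Even read as a limit, the result shows that this place, on a double-bonded chain carbon bound to a double-bonded ring carbon, allows a wider spread than the first pair revealed: propyl in place of furan-2-yl gives an at least 3.1-fold higher number from compound 2 to compound 3 (0.49 log units; beyond the scatter), and propyl in place of 2-phenylethenyl gives an at least 8.1-fold higher number from compound 1 to compound 3 (0.91 log units; beyond the scatter). Among these three compounds, the two groups that carry an aromatic ring or phenyl end give measured numbers, while propyl, with no ring, gives only the limit, and none of the three goes against this.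

The compounds shown leave open how far each step truly runs, since the limit fixes only its lower bound. They also leave open whether a longer chain such as hexyl, or a saturated ring such as cyclohexyl, would stay at the limit or return to a measured number, so the loss of the ring cannot yet be told apart from the smaller count of heavy atoms in propyl.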